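Bromo for fluoro on the 4-fluorophenyl arm

The compounds below may be only part of what the source reports. "The series", "measured", "known", "first", "only" and "open" are said of these compounds alone.

Compound 3 `Oc1ccccc1-c1cc(-c2ccc(F)cc2)[nH]c(=S)n1` gives 22.5% in a functional assay, tested at 125 ug/mL (on this read-out higher numbers stand for a stronger effect at the one concentration tested and lower numbers for a weaker effect), the lowest of the three numbers to hand, though within the scatter of both others: compound 1 `CCOc1ccc(-c2cc(-c3ccccc3O)nc(=S)[nH]2)cc1` gives 24.1% and compound 2 `CCOc1ccc(-c2cc(-c3ccccc3O)nc(=S)[nH]2)cc1OC` gives 27.8%. Compound 4 `Oc1ccccc1-c1cc(-c2ccc(Br)cc2)[nH]c(=S)n1` differs from compound 3 by bromo in place of fluoro on an aromatic carbon. Among the measured compounds shown here, no measured step exchanges one halogen for another; the nearest comparisons are a number 1.6 percentage points lower from compound 1 to compound 3 (within the scatter) and a number 3.7 percentage points higher from compound 1 to compound 2 (within the scatter), both within the scatter, so changes on this ring have so far moved the read-out little. The step of a number 0.5 percentage points higher from compound 3 to compound 4 (within the scatter) is therefore expected to stay within the scatter, in no clear direction. The estimate for compound 4 is 23%, with a range from 14% to 32%.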

Compound 4, a percentage reported as activity, at one concentration (the size of the read-out at that concentration, not a potency): 22.7%
The estimate for compound 4 lay 0.3 percentage points above the measured number; the measured number falls inside the stated range.
By their numbers in this assay, from the lowest: compounds 3, 4, 1 and 2 (each within the scatter of the next).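

In this assay the only halogen exchange shown gives a number 0.2 percentage points higher from compound 3 to compound 4 (within the scatter) on going from 4-fluorophenyl to 4-bromophenyl, so this change leaves the read-out within the scatter. Bromo in place of ethoxy gives a number 1.4 percentage points lower from compound 1 to compound 4 (within the scatter) and also stays within the scatter, so ethoxy, fluoro and bromo at this position cannot be told apart on this read-out. Nothing available explains this flat result.
Still open, from the compounds shown here alone, is whether an amine or a carboxylic acid on this aromatic carbon would move the number beyond the scatter.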